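Adding a Methoxy Group to an Anilino Thiazole Amide

This account rests on a few compounds, and the source may have more. Where it says the series, first, only, none or still open, it means among the compounds named here.

Compound 1 `Cc1nc(SCC(=O)Nc2nc(-c3ccc(Cl)cc3)cs2)n(Nc2ccccc2)c1C` was tested in a functional assay on EKVX cells (Homo sapiens) for antiproliferative activity, read by sulforhodamine B assay, with a stated time of 48 h (a lower number here means a stronger inhibitor of growth, a higher number a weaker inhibitor of growth), where compound 1 gives 1840 nM. That is the higher of the two values recorded so far; the other measured compound, compound 2 `Cc1ccc(Nn2c(SCC(=O)Nc3nc(-c4ccccc4)cs3)nc(C)c2C)cc1`, gives 1390 nM in this assay, and the two values lie within the scatter of each other, so no order between them can be read. For the measured compounds named here, compound 2 differs from compound 1 in more than one place, so no single-point step is available. Compound 3 `COc1ccc(Nn2c(SCC(=O)Nc3nc(-c4ccc(Cl)cc4)cs3)nc(C)c2C)cc1` is the unmeasured analogue. Relative to compound 1 it carries methoxy in place of hydrogen on an aromatic carbon, a methoxy in place of hydrogen on an aromatic carbon, para to a large group. Nothing in the measured pair shows how such a change shifts this assay; the expectation is a step within the scatter, in no particular direction, with a 1.2-fold lower number from compound 1 to compound 3 (0.09 log units; within the scatter) as the estimated change. Compound 3 is thus expected to give 1500 nM, within a range from 600 nM to 4000 nM.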

Compound 3, concentration for 50% growth inhibition: 1920 nM
Beside the measured number, compound 3's estimate is 1.3-fold (0.11 log units) below it; low and high end bracket the measured number.
By their numbers in this assay, from the lowest: compounds 2, 1 and 3 (each within the scatter of the next).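

Replacing the anilino group of compound 1 with (4-methoxyphenyl)amino gives a 1.0-fold higher number from compound 1 to compound 3 (0.02 log units; within the scatter) in this assay. For the compounds shown here, this is the first comparison here in which only one place differs, and it shows that compound 1 and compound 3 cannot be told apart in this assay. At this position, para to a large group, a methoxy in place of hydrogen therefore leaves no readable mark on the growth-inhibition number. No further measurement bears on this result.

As far as these compounds go, whether an amine, a carboxylic acid or a longer chain such as ethoxy at the same place would also stay within the scatter remains open. A single pair also cannot tell whether a methoxy here would give the same result on a compound lacking the chlorine.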